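Removing the aromatic chloro: compound 3 to compound 4

This account rests on a few compounds, and the source may have more. Where it says the series, first, only, none or still open, it means among the compounds named here.

Measured so far:
compound 1 `CC(=O)N[C@@H](CSC(=O)NCc1ccc(Cl)cc1)C(=O)O`: > 200000 nM
compound 2 `COc1ccccc1CNC(=O)SC[C@H](NC(C)=O)C(=O)O`: > 200000 nM
compound 3 `CC(=O)N[C@@H](CSC(=O)Nc1ccc(Cl)cc1)C(=O)O`: 24 nM

In a functional assay on UACC-62 cells (Homo sapiens) for cytotoxicity, read by MTT assay, with a stated time of 6 days (a lower number here means a stronger inhibitor, a higher number a weaker inhibitor), compound 1 reaches only a limit of the assay, > 200000 nM. Compound 2 likewise shows only a limit, > 200000 nM. Among the measured compounds shown here, compound 3 gives 24 nM in this assay, the single real number among the three; the other two sit at the limit of > 200000 nM in this assay, at which 2 of the 3 values shown sit, so compound 3 stands alone as the one inhibitor with a measured potency in this set. For the measured compounds named here, nothing here separates the effect of the aromatic chloro from the rest of the molecule, since no pair of measured compounds differs in one place.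

Compound 4 `CC(=O)N[C@@H](CSC(=O)Nc1ccccc1)C(=O)O` is the unmeasured analogue. It differs from compound 3 by hydrogen in place of chloro on an aromatic carbon. Going by the values given here, with no comparable step on record, the size of this change cannot be read from the data. The expected step is a 2.9-fold higher number from compound 3 to compound 4 (0.46 log units; beyond the scatter), leaning toward weaker inhibition but possibly within the scatter. Compound 4 is estimated at 70 nM, with a range from 15 nM to 400 nM.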

Compound 4, half-maximal inhibitory concentration: 125000 nM
Estimate against measurement, compound 4: 1800-fold (3.25 log units) below; the whole stated range lies below it.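

In this assay, hydrogen in place of chloro on an aromatic carbon, para to a large group, gives a 5200-fold higher number from compound 3 to compound 4 (3.72 log units; beyond the scatter). Among the compounds shown here, this is the first comparison that isolates one change, and it shows that the potency of compound 3 depends heavily on this single chloro, at least within this pair. Compound 4 still gives a real number, but it lies close to the ceiling reached by other compounds in the series: the limit of > 200000 nM in this assay, at which 2 of the 4 values shown sit.

Going by these compounds, whether fluoro, bromo, methyl or trifluoromethyl at this place would retain the potency of compound 3 remains open, so the step cannot yet be tied to chlorine itself rather than to any substituent there. The compounds shown also give no reason for the size of the step.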